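This account rests on a few compounds, and the source may have more. Where it says the series, first, only, none or still open, it means among the compounds named here.

Compound 1, with the structure `N=C(NCCCc1c[nH]cn1)NCCC(c1ccccc1)c1ccccn1`, is the stronger of the two compounds measured in a functional assay on ileum for antagonist activity at histamine H1 receptor (Cavia porcellus); a lower number here means a less potent compound, a higher number a more potent compound, by a factor of ten per unit of this negative logarithm. In this assay compound 1 gives 7.01. For the measured compounds named here, the other measured compound, compound 2, with the structure `c1ccc(C(CCC/N=C(/NCCCc2c[nH]cn2)NC2CCCCC2)c2ccccn2)cc1`, gives 5.56 in this assay, a number that lies beyond the scatter below that of compound 1; the two structures differ in more than one place, so the pair shows only that the two values stand apart.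

Compound 3, with the structure `N=C(NCCCc1c[nH]cn1)NCCC(c1ccc(Cl)c(Cl)c1)c1ccccn1`, has not yet been measured in this assay. It differs from compound 1 in one place: 3,4-dichlorophenyl in place of phenyl on a saturated chain carbon bound to an aromatic carbon and a saturated chain carbon. Going by the values given here, no measured pair in this set shows what such a change does, so the expected step rests on the structural change alone and on the value of compound 1 alone.

The step expected from compound 1 to compound 3 is a number 0.29 log units higher from compound 1 to compound 3 (within the scatter), a small change that may not exceed the scatter. For compound 3 the estimated value in this assay is 7.3, with a range from 6.6 to 8.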

Compound 3, negative logarithm of the antagonist equilibrium constant: 7.1
Estimate against measurement, compound 3: 0.20 log units above; low and high end bracket the measured number.
By their numbers in this assay, from the lowest: compound 2; then compounds 1 and 3 (each within the scatter of the next).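

At the saturated chain carbon bound to an aromatic carbon and a saturated chain carbon, 3,4-dichlorophenyl in place of phenyl gives a number 0.09 log units higher from compound 1 to compound 3 (within the scatter) in this assay. The earlier compounds shown here offered no step at this place, since they differ in more than one place; this pair now shows that the two added chlorine atoms on the phenyl leave the value within the scatter, so compound 1 and compound 3 cannot be told apart in this read-out. This holds for this one change on the core of compound 1, and no measurement at hand bears on the reason for the outcome.

From the compounds shown here alone, it remains open whether a phenyl carrying a single chlorine, or one carrying a methoxy group, an amine or a carboxylic acid, would also stay within the scatter of compound 1 at this place. Going by these compounds, it is equally open whether 3,4-dichlorophenyl in place of phenyl would give a similar step on the core of compound 2, whose value lies beyond the scatter below that of compound 1.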